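The source may hold more compounds than are shown below. What is called first, only, known or untested is meant among the compounds shown, and "the series" means these compounds.

Measured in a functional assay on DU-145 cells (Homo sapiens) for inhibition, read by trypan blue exclusion, with a stated time of 96 h; on this read-out lower numbers stand for stronger inhibition of growth and higher numbers for weaker inhibition of growth:
compound 1 `O=C(/C(=C\c1ccc(O)cc1O)S(=O)(=O)c1ccccc1Br)c1ccc(Br)cc1` gives a limit, > 100000 nM, not a number.
compound 2 `Cc1ccc(C)c(/C=C(\C(=O)c2ccc(Br)cc2)S(=O)(=O)Cc2ccc(F)cc2)c1` gives 1000 nM.
compound 3 `O=C(/C(=C/c1ccc(Br)cc1)S(=O)(=O)Cc1ccc(I)cc1)c1ccc(Br)cc1` gives a limit, > 50000 nM, not a number.

Going by the values given here, compound 2 stands as the only number in this assay; the two other values sit at limits, the limit of > 100000 nM in this assay, at which 1 of the 3 values shown sits, and (the limit of > 50000 nM in this assay, at which 1 of the 3 values shown sits). Compound 4 `COc1ccc(/C=C(\C(=O)c2ccc(Br)cc2)S(=O)(=O)Cc2ccc(F)cc2)cc1` differs from compound 2 by 4-methoxyphenyl in place of 2,5-dimethylphenyl on a double-bonded chain carbon bound to a double-bonded chain carbon. Among the compounds with values here, no pair of measured compounds differs in one place, so no measured step anchors this change. Compounds 1 and 3 each sit at a limit and differ from compound 2 in more than one place, so their values show only that such variants can lose activity. For compound 4 the expected step of a 2.0-fold higher number from compound 2 to compound 4 (0.30 log units; within the scatter) is small, within or just beyond the scatter, if anything toward weaker inhibition. Compound 4 is estimated at 2000 nM, ranging from 500 nM to 10000 nM.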

Compound 4, concentration for 50% growth inhibition: 25000 nM
For compound 4 the middle estimate is 13-fold (1.10 log units) below the measured one, outside the stated range (above it).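

In this assay this place on a double-bonded chain carbon bound to a double-bonded chain carbon proves sensitive: 4-methoxyphenyl in place of 2,5-dimethylphenyl gives a 25-fold higher number from compound 2 to compound 4 (1.40 log units; beyond the scatter). Going by these compounds alone, both groups carry one six-membered aromatic ring and the same count of heavy atoms, so the step is the first single-place reading and shows that a swap of substituents on that ring alone can weaken inhibition of growth. Nothing measured here accounts for the size of this step.

This one step does not separate the loss of the two methyl groups from the entry of the methoxy group. As far as these compounds go, how an amine or a carboxylic acid on that ring would read remains open.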